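A few compounds are considered here, and "the series" means these few. Any claim that something is new, unique, unknown or untested is made for them only; others in the source may bear on it.

Measured so far:
- compound 1, `N=C(N)c1ccc2[nH]c(-c3cc(F)cc(Cl)c3)cc2c1` — 82%
- compound 2, `N=C(N)c1ccc2[nH]c(-c3cc(Cl)cc(Cl)c3)cc2c1` — 92%

In an assay on isolated protein for inhibition of acid-sensing ion channel 3 (Homo sapiens), read by patch clamp, tested at 1 uM (a higher number here means more inhibition at the concentration tested (going by the name of the read-out), a lower number less inhibition), compound 1 gives 82% and compound 2 gives 92%. Compound 2 stands at the top of the two numbers shown, with compound 1 the only neighbour; the step of a number 10 percentage points higher from compound 1 to compound 2 (within the scatter) is within the scatter, so the two are not distinguished by this assay.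

Compound 3, `N=C(N)c1ccc2[nH]c(-c3cc(Cl)cc(Cl)c3Cl)cc2c1`, is not yet measured. It differs from compound 2 by chloro in place of hydrogen on an aromatic carbon. Among the measured compounds shown here, the one measured step that bears on it is a number 10 percentage points higher from compound 1 to compound 2 (within the scatter), a halogen exchange on the same ring, and that step stayed within the scatter. Nothing measured speaks to a third chloro group on this ring, so the change is treated as a further halogen variation of the same kind.

The expected step of a number 2 percentage points lower from compound 2 to compound 3 (within the scatter) is therefore none beyond the scatter. Compound 3 is estimated at 90% in this assay, with a range from 75% to 99%.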

Compound 3, a percentage reported as inhibition, at one concentration (the size of the read-out at that concentration, not a potency): 91%
Compound 3: middle estimate off by 1 percentage points, on the low side; measured number inside the range.
By their numbers in this assay, from the lowest: compounds 1, 3 and 2 (each within the scatter of the next).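

In this assay chloro in place of hydrogen on an aromatic carbon, ortho to a chloro group, ortho to a large group and para to a chloro group, gives a number 1 percentage points lower from compound 2 to compound 3 (within the scatter) and leaves compound 2 and compound 3 undistinguished. The earlier step covered only an exchange of one halogen for another, whereas this one shows that a carbon carrying hydrogen in compound 2 can take a chloro group with no difference beyond the scatter, compound 3 giving 91% in this assay at the single concentration tested. No measurement at hand offers an explanation for this result.

Open, going by these compounds, is whether a methyl, a methoxy, an amine or a carboxylic acid on this same carbon would also stay within the scatter of compound 2, or would separate from it in this assay. On these data alone, all three numbers come from one concentration and are not potencies, so how compound 1, compound 2 and compound 3 would compare across a range of concentrations also remains open.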